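The compounds below may be only part of what the source reports. "The series", "measured", "known", "first", "only" and "open" are said of these compounds alone.

Of the compounds shown here, three sharing one core have been measured in a functional assay for inhibition of sodium/hydrogen exchanger (Oryctolagus cuniculus); a lower number here means a stronger inhibitor, a higher number a weaker inhibitor. Compound 1 `Cc1cc(OC(C)C)c(S(C)(=O)=O)cc1C(=O)N=C(N)N` gives 19 nM, compound 2 `Cc1cc(C(F)(F)F)c(S(C)(=O)=O)cc1C(=O)N=C(N)N` gives 37 nM, and compound 3 `CS(=O)(=O)c1cc(C(=O)N=C(N)N)ccc1C(F)(F)F` gives 140 nM, the highest of the three numbers: from compound 2 the step is a 3.8-fold higher number from compound 2 to compound 3 (0.58 log units; beyond the scatter), and the gap to compound 1 is wider still. Compound 4 `CS(=O)(=O)c1cc(C(=O)N=C(N)N)ccc1N1CCC(N)CC1` has not yet been measured. It differs from compound 3 in one place: 4-aminopiperidin-1-yl in place of trifluoromethyl on an aromatic carbon. For the measured compounds named here, only one measured step touched that same aromatic carbon, a 1.9-fold higher number from compound 1 to compound 2 (0.29 log units; within the scatter), and it stayed small. The other step, a 3.8-fold higher number from compound 2 to compound 3 (0.58 log units; beyond the scatter), concerns a different carbon and says nothing about the incoming group. Going by the values given here, no measured compound carries a ring at that carbon, so the data give no direct guide, and the one step that does apply was small. For compound 4 a step of only a 1.1-fold higher number from compound 3 to compound 4 (0.03 log units; within the scatter) is expected, with wide uncertainty. Compound 4 is therefore expected to give about 150 nM, within 40 nM to 600 nM.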

Compound 4, half-maximal inhibitory concentration: 160 nM
Compound 4: the middle estimate sits 1.1-fold (0.03 log units) below what was measured; the range from low to high includes it.
By their numbers in this assay, from the lowest: compounds 1 and 2 (each within the scatter of the next); then compounds 3 and 4 (each within the scatter of the next).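

The swap of trifluoromethyl for 4-aminopiperidin-1-yl, on the aromatic carbon ortho to a methylsulfonyl group, gives in this assay a step of a 1.1-fold higher number from compound 3 to compound 4 (0.06 log units; within the scatter) and so no readable shift, although the entering group brings a six-membered non-aromatic ring and a hydrogen-bond donor that trifluoromethyl lacks. For the compounds shown here, the earlier swap at this carbon, between isopropoxy and trifluoromethyl, involved no ring, so this pair is the first sign that a ring-bearing group can sit here without a readable change. Nothing shown explains why the two groups score alike.

On these data alone, whether the amine on the ring matters stays open: that would take a comparison with plain piperidin-1-yl or 4-hydroxypiperidin-1-yl at this carbon. Also open, as far as these compounds go, is whether the result holds with the methyl group of compound 2 present.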